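Replacing the 4-(methylsulfanyl)benzyl group of compound 1

The compounds below may be only part of what the source reports. "The series", "measured", "known", "first", "only" and "open" are said of these compounds alone.

- compound 1 `CSc1ccc(CSc2nc(-c3ccc(F)cc3)c(-c3ccncc3)[nH]2)cc1`: 670 nM
- compound 2 `CSc1ccc(CSc2nc(-c3ccc(Cl)cc3)c(-c3ccncc3)[nH]2)cc1`: 2200 nM
- compound 3 `CSc1ccc(CSc2nc(-c3ccccc3)c(-c3ccncc3)[nH]2)cc1`: 72500 nM

In a functional assay (Homo sapiens) for inhibition (a higher number here means a weaker inhibitor, a lower number a stronger inhibitor), compound 1 has the lowest number of the three, which makes it the strongest inhibitor so far. Compound 4 `Oc1cccc(CSc2nc(-c3ccc(F)cc3)c(-c3ccncc3)[nH]2)c1` keeps the core of compound 1 and changes one group, on a saturated chain carbon bound to a sulfur: 3-hydroxyphenyl in place of 4-(methylsulfanyl)phenyl on a saturated chain carbon bound to a sulfur. Here 3-hydroxyphenyl takes the place of 4-(methylsulfanyl)phenyl.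

The measured steps all concern a different spot, a halogen or hydrogen on an aromatic carbon: a 3.3-fold higher number from compound 1 to compound 2 (0.52 log units; beyond the scatter), a 110-fold higher number from compound 1 to compound 3 (2.03 log units; beyond the scatter) and a 33-fold higher number from compound 2 to compound 3 (1.52 log units; beyond the scatter). They show that one small swap can shift the number a great deal, but none of them tests the group that changes here. The data therefore give no direction, so no step beyond the scatter is expected, though with wide uncertainty. The expected change is a 1.3-fold higher number from compound 1 to compound 4 (0.13 log units; within the scatter). Compound 4 is estimated at 900 nM, with an expected range of 200 nM to 4500 nM.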

Compound 4, half-maximal inhibitory concentration: 310 nM
Compound 4: the middle estimate sits 2.9-fold (0.46 log units) above what was measured; measured number inside the range.
By their numbers in this assay, from the lowest: compound 4; then compound 1; then compound 2; then compound 3.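

In this assay, going by these compounds alone, the step from 4-(methylsulfanyl)phenyl to 3-hydroxyphenyl is a 2.2-fold lower number from compound 1 to compound 4 (0.33 log units; beyond the scatter) and gives the first reading at this position, where the earlier compounds changed only the halogen or hydrogen on an aromatic carbon. Inhibition does not depend on keeping the 4-(methylsulfanyl)benzyl group, since it is retained and modestly improved when that group gives way to 3-hydroxybenzyl. This one step swaps the group and moves it around the ring at the same time, and nothing measured here explains its direction.

As far as these compounds go, whether the gain belongs to the hydroxyl itself or to where it sits remains open, and 4-hydroxybenzyl or 3-methoxybenzyl would help separate the two. Also open, from the compounds shown here alone, is how this position responds to an amine, a carboxylic acid or a longer chain carrying the ring.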